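A few compounds are considered here, and "the series" means these few. Any claim that something is new, unique, unknown or untested is made for them only; others in the source may bear on it.

Compound 1, `COc1ccc(/C=C2\C(=O)N(c3c(Cl)cccc3Cl)c3ccccc32)cc1`, gives > 100 ug/mL in a functional assay on MCF7 cells (Homo sapiens) for cytotoxicity, read by MTT assay, with a stated time of 72 h; a lower number here means that less compound is needed, a higher number that more compound is needed for the effect; that is a limit of the assay, not a number. Compound 2, `O=C1/C(=C\c2ccccc2[N+](=O)[O-])c2ccccc2N1c1c(Cl)cccc1Cl`, gives "not determined" (no result reported) in this assay.

Compound 2 therefore stands nowhere on the scale: no number is known for it. Compound 3, `O=C1/C(=C\c2ccccc2Cl)c2ccccc2N1c1c(Cl)cccc1Cl`, differs from compound 2 by chloro in place of nitro on an aromatic carbon. Going by the values given here, no step between measured compounds exists, so no direction or size can be foreseen for compound 3 relative to compound 2, and the sole measured entry of the series is a limit (the limit of > 100 ug/mL in this assay, at which 1 of the 2 values shown sits). Compound 3 is expected to give 80 ug/mL, within 20 ug/mL to 300 ug/mL.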

Compound 3, concentration for half-maximal effect: 9 ug/mL
Compound 3: middle estimate off by 8.9-fold (0.95 log units), on the high side; measured number outside the range, below it.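

With 2-chlorophenyl on the double-bonded chain carbon, the shared core gives a measured number in this assay, which neither earlier compound provided. Replacing 4-methoxyphenyl gives an at least 11-fold lower number from compound 1 to compound 3 (1.04 log units; beyond the scatter) and this large step lies beyond the scatter, yet one end of it is a limit, so its true size stays unknown: the limit of > 100 ug/mL in this assay, at which 1 of the 3 values shown sits.
Compound 2 has no result, so the change from nitro to chloro cannot be read.

From the compounds shown here alone, whether the step follows the chloro group itself or its place on the aromatic ring stays open. Also open, going by these compounds, is how an amine or a carboxylic acid on that aromatic carbon would compare with compound 3.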